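The source may hold more compounds than are shown below. What is called first, only, known or untested is meant among the compounds shown, and "the series" means these compounds.

Measured compounds in an ADME assay on MRC5 cells (Homo sapiens) for cytotoxicity, read by fluorescence and resazurin assay, with a stated time of 3 days; a higher number here means a weaker inhibitor, a lower number a stronger inhibitor:
- compound 1 `Cc1cn(C2CCN(Cc3cccc(Oc4cc(Cl)cc(Cl)c4)c3)CC2)c(=O)[nH]c1=O`: 6730 nM
- compound 2 `Cc1cn(C2CCN(Cc3cccc(Oc4ccc(O)cc4)n3)CC2)c(=O)[nH]c1=O`: "not determined" (no result reported)

Going by the values given here, compound 1 holds the only number in this assay; it stands alone, since compound 2 carries no value, so nothing can yet be said of its position relative to anything else. Among the compounds with values here, no step between two measured compounds is available.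

Compound 3 `Cc1cn(C2CCN(Cc3cccc(Oc4ccc(Cl)c(Cl)c4)c3)CC2)c(=O)[nH]c1=O` is built from compound 1 by the change (3,4-dichlorophenyl in place of 3,5-dichlorophenyl on an oxygen on an aromatic ring), a rearrangement of the same atoms. Without any comparable pair in the set, the expectation rests only on compound 1 having given 6730 nM in this assay. The step from compound 1 to compound 3 is expected to be small, a 1.1-fold lower number from compound 1 to compound 3 (0.05 log units; within the scatter), not clearly in either direction and likely within the scatter. Compound 3 is therefore estimated at 6000 nM in this assay, with a range from 2500 nM to 15000 nM.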

Compound 3, half-maximal inhibitory concentration: 6100 nM
The estimate for compound 3 lay 1.0-fold (0.01 log units) below the measured number, and the stated range covers the measured number.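

this assay shows a 1.1-fold lower number from compound 1 to compound 3 (0.04 log units; within the scatter) with 3,4-dichlorophenyl in place of 3,5-dichlorophenyl on an oxygen on an aromatic ring. Going by these compounds alone, this is the first reading of this position, and the two chlorine patterns cannot be told apart here, so the number for compound 1 is not tied to the 3,5-dichlorophenyl arrangement alone. No measured property of either group bears on this result.

Still open, from the compounds shown here alone, is whether the chlorines matter at all, since both compounds carry the same two atoms and only their arrangement differs. An unsubstituted phenyl, or an amine or a carboxylic acid in place of the chlorines, would show whether this position can shift the number beyond the scatter.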